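Butylamino in place of morpholin-4-yl on a carbonyl carbon

The source may hold more compounds than are shown below. What is called first, only, known or untested is meant among the compounds shown, and "the series" means these compounds.

Measured in a functional assay on A549 cells (Homo sapiens) for inhibition, read by sulforhodamine B assay, with a stated time of 72 h; a higher number here means a weaker inhibitor, a lower number a stronger inhibitor:
- compound 1 `CC1CN(C(=O)c2c(N)sc(-c3ccc(Cl)cc3)c2-c2ccc(Cl)cc2)CCN1`: 4930 nM
- compound 2 `Nc1sc(-c2ccc(Cl)cc2)c(-c2ccc(Cl)cc2)c1C(=O)Nc1ccccc1`: 25000 nM
- compound 3 `Nc1sc(-c2ccc(Cl)cc2)c(-c2ccc(Cl)cc2)c1C(=O)N1CCOCC1`: 1870 nM

Compound 3 has the lowest number of the three in this assay, and its steps to both others lie beyond the scatter. The next compound, compound 4 `CCCCNC(=O)c1c(N)sc(-c2ccc(Cl)cc2)c1-c1ccc(Cl)cc1`, carries butylamino in place of morpholin-4-yl on a carbonyl carbon.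

Among the measured compounds shown here, the closest precedent is anilino, also an amino group without a saturated ring, and going from it to morpholin-4-yl gave a large step: a 13-fold lower number from compound 2 to compound 3 (1.13 log units; beyond the scatter). The change between the two ring groups gave a modest step: a 2.6-fold lower number from compound 1 to compound 3 (0.42 log units; beyond the scatter). Anilino also gave a modest rise against 3-methylpiperazin-1-yl: a 5.1-fold higher number from compound 1 to compound 2 (0.71 log units; beyond the scatter). Butylamino is not aromatic, so compound 2 is only a partial guide, and no open-chain group has been measured yet.

A higher number is therefore expected, with a step of modest to large size. The expected step is a 3.7-fold higher number from compound 3 to compound 4 (0.57 log units; beyond the scatter). Compound 4 is estimated at 7000 nM, with an expected range of 2000 nM to 22000 nM.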

Compound 4, half-maximal inhibitory concentration: 8170 nM
Compound 4: middle estimate off by 1.2-fold (0.07 log units), on the low side; the range from low to high includes it.
By their numbers in this assay, from the lowest: compound 3; then compounds 1 and 4 (each within the scatter of the next); then compound 2.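

In this assay, among the compounds shown here, butylamino gives the first reading for an open-chain group on this carbonyl carbon: morpholin-4-yl keeps its lead, with a 4.4-fold higher number from compound 3 to compound 4 (0.64 log units; beyond the scatter), while butyl on the amide-type nitrogen improves on phenyl, with a 3.1-fold lower number from compound 2 to compound 4 (0.49 log units; beyond the scatter), so an amide hydrogen does not by itself tie the number to the level of compound 2. Butylamino and 3-methylpiperazin-1-yl cannot be separated, with a 1.7-fold higher number from compound 1 to compound 4 (0.22 log units; within the scatter), so a saturated ring is not required to reach that level. No measurement at hand accounts for these differences.

From the compounds shown here alone, it remains open whether the lead of morpholin-4-yl depends on its ring oxygen, which piperidin-1-yl would test, or on the absence of the amide hydrogen, which methyl(butyl)amino would test. Going by these compounds, the effect of chain length is also open, and ethylamino and hexylamino would begin to define it.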